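Fluoro for amino on the alkyne-linked aryl of compound 1

This account rests on a few compounds, and the source may have more. Where it says the series, first, only, none or still open, it means among the compounds named here.

Compound 1 `COC(=O)c1sc2cc(C#Cc3ccc(N)cc3)cnc2c1N` is the reference point of the series. In a functional assay on A375-C5 cells (Homo sapiens) for inhibition, read by sulforhodamine B assay, with a stated time of 48 h (a higher number here means a weaker inhibitor of growth, a lower number a stronger inhibitor of growth), compound 1 gives 4800 nM, the lowest of the two numbers recorded here. Compound 3 `COC(=O)c1sc2cc(C#Cc3ccc(N(C)C)cc3)cnc2c1N` gives 17700 nM in this assay. Compound 2 `COC(=O)c1sc2cc(C#Cc3ccccc3OC)cnc2c1N` reaches only a limit of this assay, > 47300 nM. Both measured steps run toward weaker growth inhibition: a 3.7-fold higher number from compound 1 to compound 3 (0.57 log units; beyond the scatter), and an at least 9.8-fold higher number from compound 1 to compound 2 (0.99 log units; beyond the scatter), the latter resting on a limit, (the limit of > 47300 nM in this assay, at which 1 of the 3 values shown sits).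

Compound 4 `COC(=O)c1sc2cc(C#Cc3ccc(F)cc3)cnc2c1N` differs from compound 1 in one place: fluoro in place of amino on an aromatic carbon. The change sits at the same place as the change from compound 1 to compound 3, so that modest step is the closer guide, while the step to compound 2 shows that the larger reshaping of this aryl group can push the number out to the limit. A modest move toward a higher number in this assay, comparable in size to the step to compound 3, is expected for compound 4. Compound 4 is therefore expected to give 14000 nM in this assay, within 5000 nM to 45000 nM. For compound 4 the expected step is a 2.9-fold higher number from compound 1 to compound 4 (0.46 log units; beyond the scatter).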

Compound 4, concentration for 50% growth inhibition: 48400 nM
For compound 4 the middle estimate is 3.5-fold (0.54 log units) below the measured one, outside the stated range (above it).
By their numbers in this assay, from the lowest: compound 1; then compound 3; then compound 4.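

Fluoro at this place gives a 10-fold higher number from compound 1 to compound 4 (1.00 log units; beyond the scatter) in this assay, the largest readable step in the series so far, so the amino group of compound 1 cannot be exchanged for fluoro without a clear loss of growth inhibition. Fluoro also stands apart from the alkylated nitrogen, with a 2.7-fold higher number from compound 3 to compound 4 (0.44 log units; beyond the scatter), so among the three groups on this aromatic carbon para to a large group the numbers rise from amino through dimethylamino to fluoro, and no compound with a group at this place goes against that order. The step between compound 2 and compound 4 cannot be read, as it rests on a limit: the limit of > 47300 nM in this assay, at which 1 of the 4 values shown sits.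

Going by these compounds, whether the nitrogen itself sets the low number of compound 1 remains open. A methylamino or hydroxyl group at this place would separate the nitrogen from the hydrogen on it.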